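This account rests on a few compounds, and the source may have more. Where it says the series, first, only, none or still open, it means among the compounds named here.

Working notes on the arylsulfonyl series.

Compound 1 `CC1CCN(c2c(S(=O)(=O)c3cc(Cl)cc(Cl)c3)cnc3c(F)cccc23)CC1` is measured in an assay on isolated protein for displacement of a labelled ligand from metabotropic glutamate receptor 5 (Homo sapiens), with a stated time of 60 min, tested at 1 uM (on this read-out lower numbers stand for less inhibition and higher numbers for more inhibition at the one concentration tested (going by the name of the read-out)), where compound 1 gives 82%. Two further members are measured alongside it: compound 2 `CC1CCN(c2c(S(=O)(=O)c3ccc(C#N)cc3)cnc3cc(F)ccc23)CC1` gives 83% in this assay, and compound 3 `Cc1ccc(S(=O)(=O)c2cnc3ccc(F)cc3c2N2CCC(C)CC2)cc1F` gives 86%. The three numbers sit within the usual scatter of one another, so compound 1 stands on a level with compound 2 and compound 3 and no order among the three can be read from them.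

Compound 4 `Cc1ccc(S(=O)(=O)c2cnc3c(F)cccc3c2N2CCC(C)CC2)cc1` has not been measured in this assay. It differs from compound 1 in one place: 4-methylphenyl in place of 3,5-dichlorophenyl on a sulfonyl sulfur. Going by the values given here, no measured pair in the set isolates this change, so there is nothing to take a step size from. Compound 3, which carries a closely related aryl group on the sulfonyl sulfur, gives 86%, and the whole set shows a flat response to variation at this position. Compound 4 is therefore expected to stay within the scatter, with the step from compound 1 to compound 4 estimated at a number 2 percentage points higher from compound 1 to compound 4 (within the scatter). Compound 4 is estimated at 84% in this assay, with a range from 72% to 93%.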

Compound 4, a percentage reported as inhibition, at one concentration (the size of the read-out at that concentration, not a potency): 93%
Estimate against measurement, compound 4: 9 percentage points below; low and high end bracket the measured number.
By their numbers in this assay, from the lowest: compounds 1, 2, 3 and 4 (each within the scatter of the next, the first and the last beyond it).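

In this assay the change to 4-methylphenyl in place of 3,5-dichlorophenyl on a sulfonyl sulfur gives a number 11 percentage points higher from compound 1 to compound 4 (beyond the scatter). Going by these compounds alone, this is the first pair that isolates this position, and it shows that the position is not silent: the flat picture from the earlier numbers does not hold across this one change, although the step is modest and rests on a single pair. No measured evidence bears on why the two aryl groups read differently.

As far as these compounds go, it stays open whether the step comes from losing the two chlorines or from gaining the methyl, and a plain phenyl or a 4-methoxyphenyl on the sulfonyl sulfur would help to separate the two. From the compounds shown here alone, whether the same change gives a similar step on the core of compound 3 also stays open.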